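A few compounds are considered here, and "the series" means these few. Any claim that something is new, unique, unknown or untested is made for them only; others in the source may bear on it.

In a functional assay on SK-OV-3 cells (Homo sapiens) for inhibition, read by sulforhodamine B assay, with a stated time of 48 h (on this read-out lower numbers stand for stronger inhibition of growth and higher numbers for weaker inhibition of growth), compound 1 `O=C(Cc1csc2nc(-c3ccc(Br)cc3)cn12)N/N=C/c1ccccc1` gives > 100000 nM, which is a limit and not a number. Among the measured compounds shown here, compound 2 `O=C(Cc1csc2nc(-c3ccc(Br)cc3)cn12)N/N=C/c1ccccc1O` gives 30200 nM, the only actual number so far. For the measured compounds named here, the single measured step, hydroxy in place of hydrogen on an aromatic carbon, is an at least 3.3-fold lower number from compound 1 to compound 2 (0.51 log units; beyond the scatter), and it starts from the limit of > 100000 nM in this assay, at which 1 of the 2 values shown sits. Compound 3 `O=C(Cc1csc2nc(-c3ccc(Br)cc3)cn12)N/N=C/c1ccc(O)cc1` differs from compound 2 by 4-hydroxyphenyl in place of 2-hydroxyphenyl on a carbon with a double bond to nitrogen. Going by the values given here, the measured step bears on this only indirectly: compound 3 keeps the hydroxy, and no measured step shows what moving it does. With compound 2 at 30200 nM as the anchor, no step beyond the scatter is expected in this assay. The expected change is a 1.3-fold higher number from compound 2 to compound 3 (0.12 log units; within the scatter). Compound 3 is estimated at 40000 nM, with an expected range of 15000 nM to 100000 nM.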

Compound 3, concentration for total growth inhibition: > 100000 nM
Compound 3 ended at the assay's limit (the forecaster's own chance of this, stated with the estimate: 20%); at least 2.5-fold (0.39 log units) between middle value and limit.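

In this assay, the presence of a hydroxy is not enough on its own, as 4-hydroxyphenyl in place of 2-hydroxyphenyl on a carbon with a double bond to nitrogen gives an at least 3.3-fold higher number from compound 2 to compound 3 (0.51 log units; beyond the scatter). Among the compounds shown, the gain in growth inhibition therefore goes with 2-hydroxyphenyl and not with the hydroxy as such. The comparison of compound 1 with compound 3 cannot be read, since both values are limits: the limit of > 100000 nM in this assay, at which 2 of the 3 values shown sit.

Among the compounds shown here, compound 2, at 30200 nM, remains the only actual number, so the size of the effect of either change on the scale of this read-out stays undefined. Open, going by these compounds, is whether a methoxy or an amine in place of the hydroxy of 2-hydroxyphenyl would keep, strengthen or lose the growth inhibition seen with compound 2.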